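This account rests on a few compounds, and the source may have more. Where it says the series, first, only, none or still open, it means among the compounds named here.

Measured compounds in an assay on lysate for inhibition of phosphatidylcholine:ceramide cholinephosphotransferase 2 (Homo sapiens), read by HPLC, with stated times of 30 min and 2 h; on this read-out lower numbers stand for stronger inhibition and higher numbers for weaker inhibition:
compound 1 `O=C(Nc1cccnc1)c1ccccc1OCc1ccccc1` gives 3200 nM
compound 2 `O=C(Nc1cccnc1)c1ccccc1OCc1ccccc1Cl` gives 1100 nM
compound 3 `N#Cc1ccccc1COc1ccccc1C(=O)Nc1cccnc1` gives 31800 nM

Compound 3 stands highest of the three numbers in this assay, with compound 1 nearest and compound 2 furthest. Compound 4 `O=C(Nc1cccnc1)c1ccccc1OCc1cccc(F)c1` differs from compound 3 by 3-fluorophenyl in place of 2-cyanophenyl on a saturated chain carbon bound to an oxygen on an aromatic ring. For the measured compounds named here, two measured steps bear on this change: the cyano group raised the number, seen as a 9.9-fold higher number from compound 1 to compound 3 (1.00 log units; beyond the scatter) and a 29-fold higher number from compound 2 to compound 3 (1.46 log units; beyond the scatter), and a halogen on this ring gave a 2.9-fold lower number from compound 1 to compound 2 (0.46 log units; beyond the scatter). Removing the cyano group is therefore expected to lower the number in this assay, back toward compound 1, while the fluorine is not expected to move it far. Compound 4 is expected at 2500 nM, within 800 nM to 8000 nM, an estimated step of a 13-fold lower number from compound 3 to compound 4 (1.10 log units; beyond the scatter).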

Compound 4, half-maximal inhibitory concentration: 1600 nM
Beside the measured number, compound 4's estimate is 1.6-fold (0.19 log units) above it, within the range that was stated.
By their numbers in this assay, from the lowest: compounds 2, 4 and 1 (each within the scatter of the next, the first and the last beyond it); then compound 3.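

Replacing 2-cyanophenyl with 3-fluorophenyl in this assay gives a 20-fold lower number from compound 3 to compound 4 (1.30 log units; beyond the scatter), so compound 3's high number does not extend to this fluorinated ring. With a 2.0-fold lower number from compound 1 to compound 4 (0.30 log units; within the scatter) and a 1.5-fold higher number from compound 2 to compound 4 (0.16 log units; within the scatter), both within the scatter, only the nitrile-bearing compound 3 stands apart among these four compounds. No evidence is available to explain this difference.

This change alters both the group and its place on the ring, so the compounds leave open which of the two matters. From the compounds shown here alone, whether a methoxy group or an amine here would track the nitrile or the halogens also remains open.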